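The source may hold more compounds than are shown below. What is called first, only, known or untested is meant among the compounds shown, and "the series" means these compounds.

Measured compounds:
- compound 1 `Cc1oc(-c2ccc(Cl)cc2)nc1C(=O)N[C@H]1CN(S(=O)(=O)c2ccccc2)C[C@@H]1C(=O)N[C@H]1CCCNC1`: 87% in a functional assay on HEK293 cells for agonist activity at growth hormone secretagogue receptor type 1 (Homo sapiens), read by HTRF and inositol phosphate accumulation, with a stated time of 90 min, in the presence of a further agent that is not named here; on this read-out lower numbers stand for smaller maximal responses and higher numbers for larger maximal responses
- compound 2 `Cc1oc(-c2ccc(C(F)(F)F)cc2)nc1C(=O)N[C@H]1CN(S(=O)(=O)c2ccccc2)C[C@@H]1C(=O)N[C@H]1CCCNC1`: 85%

Compound 2 stands lowest of the two numbers, yet its nearest neighbour, compound 1, lies only a step away that the data call within the scatter: a number 2 percentage points lower from compound 1 to compound 2 (within the scatter). The two compounds therefore cannot be told apart on this read-out; the shared core carries either a chloro or a trifluoromethyl group on the same aromatic carbon, and the maximal response stays where it was.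

Compound 3 `Cc1oc(-c2ccccc2Cl)nc1C(=O)N[C@H]1CN(S(=O)(=O)c2ccccc2)C[C@@H]1C(=O)N[C@H]1CCCNC1` brings a different kind of change: 2-chlorophenyl in place of 4-(trifluoromethyl)phenyl on an aromatic carbon. Among the compounds with values here, no measured pair covers such a move of the substituent around the attached ring, so the only step that bears on it is the one from compound 1 to compound 2, which was within the scatter. The data give no ground for a large shift in either direction; the wider uncertainty comes from the change itself lacking any direct precedent. The expected step is a number 5 percentage points lower from compound 2 to compound 3 (within the scatter). Compound 3 is estimated at 80%, within a range of 60% to 95%.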

Compound 3, largest response reached (Emax), in percent of the reference or control that the assay uses in the growth hormone secretagogue receptor type 1 assay: 102%
The estimate for compound 3 lay 22 percentage points below the measured number; the whole stated range lies below it.
By their numbers in the growth hormone secretagogue receptor type 1 assay, from the lowest: compounds 2 and 1 (each within the scatter of the next); then compound 3.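

In the growth hormone secretagogue receptor type 1 assay, 2-chlorophenyl in place of 4-chlorophenyl gives a number 15 percentage points higher from compound 1 to compound 3 (beyond the scatter), and 2-chlorophenyl in place of 4-(trifluoromethyl)phenyl gives a number 17 percentage points higher from compound 2 to compound 3 (beyond the scatter), so changing this aromatic ring can shift the maximal response, which the swap of chloro for trifluoromethyl between compound 1 and compound 2 did not show. Compound 1 and compound 3 carry the same chlorophenyl group with the chlorine placed differently, so among these three compounds the place of the chlorine on the ring makes a readable difference, while the choice of chloro or trifluoromethyl in the 4-position does not. In a physicochemical assay for solubility, at pH 7.4 (a lower number here means a less soluble compound, a higher number a more soluble compound), compound 2 gives 13000 nM and compound 3 gives 10000 nM, which is a 1.3-fold lower number from compound 2 to compound 3 (0.11 log units; within the scatter), so the higher maximal response of compound 3 comes with no readable difference in solubility from compound 2.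

Nothing at hand explains why the 2-chlorophenyl group gives the larger maximal response. From the compounds shown here alone, it also remains open whether a trifluoromethyl group, a methoxy group or an amine placed where 2-chlorophenyl carries its chlorine would give the same rise, which would show whether the place on the ring or the chlorine itself counts.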